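Cyclopentylamino Imidazole in Place of Methyl Oxazole

The source may report more compounds than this note shows. Statements on the series, on what has been measured and on what is new or still open speak of the compounds shown alone.

Compound 1 `Fc1ccc(-c2nn3c(NC4CCCC4)cccc3c2-c2cc(NC3CCCC3)ncn2)cc1` was tested in an ADME assay on Vero cells (Chlorocebus sabaeus) for cytotoxicity; on this read-out lower numbers stand for higher toxicity in this test and higher numbers for lower toxicity in this test. For compound 1 the result is a limit of the test rather than a number, > 40000 nM. Compound 2 `Cc1nc(-c2c(-c3ccc(F)cc3)nn3c(NC4CCCC4)cccc23)co1` has no result in this assay: for compound 2 the entry reads "not determined" (no result reported). Going by the values given here, compound 2 thus stands without a number of its own, and the only other value shown is the limit of > 40000 nM in this assay, at which 1 of the 2 values shown sits. Compound 3 `Fc1ccc(-c2nn3c(NC4CCCC4)cccc3c2-c2c[nH]c(NC3CCCC3)n2)cc1` differs from compound 2 in one place: 2-(cyclopentylamino)-1H-imidazol-4-yl in place of 2-methyl-1,3-oxazol-4-yl on an aromatic carbon. Among the compounds with values here, with no measured step to draw on, the change from compound 2 to compound 3 is expected to shift the reading in this assay by no more than the usual scatter. Compound 3 is therefore expected to give 40000 nM, within 15000 nM to 80000 nM.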

Compound 3, half-maximal cytotoxic concentration: 40000 nM
Beside the measured number, compound 3's estimate shows no gap at the digits printed; the range from low to high includes it.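

The step from compound 2 to compound 3 cannot be read: compound 2 has no number to set against compound 3 at 40000 nM. As far as these compounds go, what swapping 2-methyl-1,3-oxazol-4-yl for 2-(cyclopentylamino)-1H-imidazol-4-yl does in this assay stays open.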